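A few compounds are considered here, and "the series" means these few. Any claim that something is new, unique, unknown or untested is made for them only; others in the source may bear on it.

In a functional assay on MKN-45 cells (Homo sapiens) for cytotoxicity, read by MTT assay, with a stated time of 72 h (on this read-out lower numbers stand for stronger inhibition and higher numbers for weaker inhibition), compound 1 `COc1cc2c(Oc3ccc(NC(=O)c4nnn(-c5ccc(C)cc5)c4C(F)(F)F)cc3F)ccnc2cc1OCCCN1CCC(C)CC1` gives 140 nM, the highest of the three numbers, though its companions sit close by: compound 2 `COc1cc2c(Oc3ccc(NC(=O)c4nnn(-c5ccccc5C(F)(F)F)c4C(F)(F)F)cc3F)ccnc2cc1OCCCN1CCC(C)CC1` gives 100 nM and compound 3 `COc1cc2c(Oc3ccc(NC(=O)c4nnn(-c5cccc(Br)c5)c4C(F)(F)F)cc3F)ccnc2cc1OCCCN1CCC(C)CC1` gives 120 nM, with a 1.4-fold lower number from compound 1 to compound 2 (0.15 log units; within the scatter) and a 1.2-fold lower number from compound 1 to compound 3 (0.07 log units; within the scatter). Compound 4 `COc1cc2c(Oc3ccc(NC(=O)c4nnn(-c5ccc(C)cc5)c4C(F)(F)F)cc3F)ccnc2cc1OCCCN1CCN(C)CC1` differs from compound 1 by 4-methylpiperazin-1-yl in place of 4-methylpiperidin-1-yl on a saturated chain carbon, three bonds along the chain from an oxygen on an aromatic ring. Among the compounds with values here, none of the measured steps touches this part of the molecule; each of them swaps the aryl group on the aromatic nitrogen and stays within the scatter. The step from compound 1 to compound 4 is therefore expected to be small, with no direction to favour, and compound 4 is estimated at 140 nM in this assay, between 60 nM and 350 nM, which corresponds to no change at the digits printed from compound 1 to compound 4 (within the scatter).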

Compound 4, half-maximal inhibitory concentration: 140 nM
The estimate for compound 4 equals the measured number at the digits printed; the range from low to high includes it.
By their numbers in this assay, from the lowest: compounds 2, 3, 1 and 4 (each within the scatter of the next).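

Within the data shown here, the earlier compounds varied only the aryl group on the aromatic nitrogen, so this is the first reading at the far end of the saturated chain. In this assay, 4-methylpiperazin-1-yl in place of 4-methylpiperidin-1-yl gives no change at the digits printed from compound 1 to compound 4 (within the scatter), so a second ring nitrogen here leaves the number within the scatter. Nothing available offers an explanation for this result.

The compounds shown leave open whether a morpholine ring, a dimethylamine or a shorter chain at this position would also leave the number within the scatter. They also leave open whether 4-methylpiperazin-1-yl would read the same alongside 3-bromophenyl or 2-(trifluoromethyl)phenyl.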